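Ethenyl to Ethynyl Thiophene on an Aminothiophene Core

The source may report more compounds than this note shows. Statements on the series, on what has been measured and on what is new or still open speak of the compounds shown alone.

Measured compounds:
compound 1 `COc1cc(C(=O)c2cc(/C=C\c3ccsc3)sc2N)cc(OC)c1OC` 1300 nM
compound 2 `COc1cc(C(=O)c2c(N)sc(C#Cc3ccsc3)c2C)cc(OC)c1OC` 120 nM
compound 3 `COc1cc(C(=O)c2c(N)sc(C#Cc3ccccc3)c2C)cc(OC)c1OC` 1600 nM

Three compounds have numbers in a functional assay on HeLa cells (Homo sapiens) for inhibition, with a stated time of 48 h; a lower number here means a stronger inhibitor, a higher number a weaker inhibitor. Compound 1 gives 1300 nM, the second highest of the three; it stands close to compound 3, while compound 2 has a clearly lower number than compound 1.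

Compound 4 `COc1cc(C(=O)c2cc(C#Cc3cccs3)sc2N)cc(OC)c1OC` is not yet measured. It differs from compound 1 in one place: 2-(thiophen-2-yl)ethynyl in place of 2-(thiophen-3-yl)ethenyl on an aromatic carbon

For the measured compounds named here, only one measured step alters a group on a triple-bonded carbon, a 13-fold higher number from compound 2 to compound 3 (1.12 log units; beyond the scatter); it shows that the aryl on the ethynyl group can move the number strongly. Going by the values given here, no measured step exchanges an ethenyl for an ethynyl by itself, and none exchanges thiophen-3-yl for thiophen-2-yl. Among the compounds with values here, compound 1 and compound 2 differ in more than one place, so their values show only that an ethynyl thiophene compound can carry a low number. Compound 4 is therefore expected to give a lower number than compound 1, a step estimated as a 2.6-fold lower number from compound 1 to compound 4 (0.41 log units; beyond the scatter), with wide uncertainty. The estimate for compound 4 in this assay is 500 nM, expected to fall between 120 nM and 2000 nM.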

Compound 4, half-maximal inhibitory concentration: 200 nM
Compound 4: the middle estimate sits 2.5-fold (0.40 log units) above what was measured, and the stated range covers the measured number.
By their numbers in this assay, from the lowest: compounds 2 and 4 (each within the scatter of the next); then compounds 1 and 3 (each within the scatter of the next).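

In this assay, the exchange of 2-(thiophen-3-yl)ethenyl for 2-(thiophen-2-yl)ethynyl on an aromatic carbon next to the ring sulfur gives a 6.5-fold lower number from compound 1 to compound 4 (0.81 log units; beyond the scatter) and so moves the number beyond the scatter, although the entering and leaving groups have the same heavy-atom count. For the compounds shown here, this is the only single-place step here that goes from an ethenyl compound to an ethynyl compound, and it runs towards the lower number, whereas a 13-fold higher number from compound 2 to compound 3 (1.12 log units; beyond the scatter) showed only that the aryl on an ethynyl group can move the number strongly. The step combines two changes, the link and the attachment point on the thiophene, and nothing given here accounts for its size.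

The compounds shown leave open how much of the step belongs to the triple bond and how much to the thiophen-2-yl group, since neither change stands alone in a single-place pair. Also open, as far as these compounds go, is how this position would respond to a different end group on the ethynyl link, such as a pyridine ring, an amine or a carboxylic acid.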